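This account rests on a few compounds, and the source may have more. Where it says the series, first, only, none or still open, it means among the compounds named here.

Compound 1 `CCCCCOC(=O)Nc1nc(=O)n([C@@H]2O[C@H](C)[C@H]3OC(=O)O[C@H]32)cc1F`: 80 ug/mL
Compound 2 `C[C@H]1O[C@@H](n2cc(F)c(NC(=O)Oc3ccc([N+](=O)[O-])cc3)nc2=O)[C@@H]2OC(=O)O[C@@H]21`: 30 ug/mL
Compound 3 `CCC(C)COC(=O)Nc1nc(=O)n([C@@H]2O[C@H](C)[C@H]3OC(=O)O[C@H]32)cc1F`: 180 ug/mL

In a functional assay on HeLa cells (Homo sapiens) for cytotoxicity, read by MTT assay, with a stated time of 3 days (on this read-out higher numbers stand for weaker inhibition and lower numbers for stronger inhibition), compound 3 stands highest of the three numbers. Nearest to it is compound 1, as shown by a 2.3-fold higher number from compound 1 to compound 3 (0.35 log units; beyond the scatter); furthest is compound 2, as shown by a 6.0-fold higher number from compound 2 to compound 3 (0.78 log units; beyond the scatter). Compound 4 `CC(C)CCOC(=O)Nc1nc(=O)n([C@@H]2O[C@H](C)[C@H]3OC(=O)O[C@H]32)cc1F` differs from compound 3 by isobutyl in place of sec-butyl on a saturated chain carbon bound to an oxygen next to a carbonyl group. For the measured compounds named here, the only step bearing on this change is a 2.3-fold higher number from compound 1 to compound 3 (0.35 log units; beyond the scatter), where moving a branch onto the chain raised the number modestly. In compound 4 the branch sits one carbon further from the oxygen, so a partial return toward compound 1 is expected, a modest lowering of a 1.5-fold lower number from compound 3 to compound 4 (0.18 log units; within the scatter), possibly not beyond the scatter. Compound 4 is estimated at 120 ug/mL, with a range of 60 ug/mL to 250 ug/mL.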

Compound 4, half-maximal inhibitory concentration: 130 ug/mL
Estimate against measurement, compound 4: 1.1-fold (0.03 log units) below, and the stated range covers the measured number.
By their numbers in this assay, from the lowest: compound 2; then compounds 1, 4 and 3 (each within the scatter of the next, the first and the last beyond it).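

In this assay the isopentyl and 2-methylbutyl esters are not separated: the shift of the branch gives a 1.4-fold lower number from compound 3 to compound 4 (0.14 log units; within the scatter), and branching the chain gives a 1.6-fold higher number from compound 1 to compound 4 (0.21 log units; within the scatter). Among the groups on this oxygen, only 4-nitrophenyl stands apart, with a 4.3-fold higher number from compound 2 to compound 4 (0.64 log units; beyond the scatter). Nothing measured here explains these numbers.

Open, as far as these compounds go, is whether a plain phenyl group behaves like 4-nitrophenyl, which would show if compound 2 reflects the aryl ring or its nitro group. Also open, from the compounds shown here alone, is how a chain longer than pentyl, or one ending in an amine or a carboxylic acid, reads in this assay.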